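Aromatic substituent changes on the shared core

The compounds below may be only part of what the source reports. "The series", "measured", "known", "first", "only" and "open" are said of these compounds alone.

Measured so far:
compound 1, `CC(C)(O)c1cncc(-n2ncc3ccccc32)c1`, 15 nM
compound 2, `CC(C)(O)c1cncc(-n2ncc3cc(C#N)ccc32)c1`, 1160 nM
compound 3, `CC(C)(O)c1cncc(-n2ncc3c(F)cccc32)c1`, 7.58 nM

All three are ranked in an assay on cells for inhibition of cytochrome P450 11B2, mitochondrial (Homo sapiens), read by HTRF, with stated times of 1 h and 3 h; on this read-out lower numbers stand for stronger inhibition and higher numbers for weaker inhibition. Compound 3 gives the lowest number of the three, but the gap to compound 1 is within the scatter, as a 2.0-fold lower number from compound 1 to compound 3 (0.30 log units; within the scatter) shows, so the two cannot be placed in order. Compound 2 stands far apart: the step of a 77-fold higher number from compound 1 to compound 2 (1.89 log units; beyond the scatter) is large and well beyond the scatter.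

Compound 4, `COC(=O)c1cccc2c1cnn2-c1cncc(C(C)(C)O)c1`, has not yet been measured. It differs from compound 3 in one place: methoxycarbonyl in place of fluoro on an aromatic carbon. Among the measured compounds shown here, two measured steps bear on this change. The fluoro itself carries little weight, as a 2.0-fold lower number from compound 1 to compound 3 (0.30 log units; within the scatter) is within the scatter, so its loss is expected to matter little. The only substituent larger than fluoro among the measured compounds is the cyano of compound 2, and a 77-fold higher number from compound 1 to compound 2 (1.89 log units; beyond the scatter) shows a large rise in the number. A methoxycarbonyl is larger still, so a rise beyond the scatter in this assay is expected, though with wide uncertainty. For compound 4 the estimate is 150 nM, with a range from 30 nM to 800 nM. This estimate corresponds to an expected step of a 20-fold higher number from compound 3 to compound 4 (1.30 log units; beyond the scatter).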

Compound 4, half-maximal inhibitory concentration: 22 nM
Compound 4: middle estimate off by 6.8-fold (0.83 log units), on the high side; measured number outside the range, below it.
By their numbers in this assay, from the lowest: compounds 3, 1 and 4 (each within the scatter of the next, the first and the last beyond it); then compound 2.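

Among the compounds shown here, at this aromatic carbon of the shared core, methoxycarbonyl, with its 4 heavy atoms and 2 hydrogen-bond acceptors, is accommodated in this assay: the result is a 1.5-fold higher number from compound 1 to compound 4 (0.17 log units; within the scatter), so hydrogen and methoxycarbonyl cannot be placed in order here, while the modest 2.9-fold higher number from compound 3 to compound 4 (0.46 log units; beyond the scatter) is the only step of this change beyond the scatter. The large 77-fold higher number from compound 1 to compound 2 (1.89 log units; beyond the scatter) is therefore not a general outcome of putting a group larger than fluoro on the six-membered aromatic ring, since compound 4 goes against any such pattern, and the number of heavy atoms alone does not account for the series. No measurement shown offers an explanation for the difference between compound 2 and compound 4.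

Still open, going by these compounds, is whether this carbon also tolerates the corresponding carboxylic acid, a primary amide, an amine or a longer ester such as ethoxycarbonyl, any of which would show how far the result for methoxycarbonyl extends. The compounds shown also leave open how a nitrile behaves at this same carbon, and how methoxycarbonyl behaves at the carbon that bears the nitrile in compound 2.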